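A few compounds are considered here, and "the series" means these few. Any claim that something is new, unique, unknown or untested is made for them only; others in the source may bear on it.

Measured so far: compound 1 `C=C=CCN(C)Cc1ccccc1` with 8200 nM in an assay on isolated protein for inhibition of Monoamine oxidase (Rattus norvegicus) (on this read-out higher numbers stand for weaker inhibition and lower numbers for stronger inhibition), and compound 2 `C=C=C(CN)Cc1ccc(Cl)cc1` with 260 nM.

Compound 1 has the highest of the two numbers. Compound 2, its nearest neighbour, gives a much lower number, and the gap between the two is beyond the usual scatter; the two structures differ in more than one place, so nothing more is read from that pair.

The step under consideration leads from compound 1 to compound 3 `C=C=CCNCc1ccccc1`, which is yet to be measured in this assay. The change is hydrogen in place of methyl on an amine nitrogen whose other neighbours are a saturated chain carbon and a saturated chain carbon. Among the compounds with values here, no measured pair shows this change, so its effect is unknown here. A change of this kind is expected to move the number only modestly, if at all, and in either direction within roughly the scatter, with a slight lean towards a weaker result, as a 1.5-fold higher number from compound 1 to compound 3 (0.17 log units; within the scatter) expresses. Compound 3 is therefore estimated at 12000 nM, within the range 3000 nM to 45000 nM.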

Compound 3, half-maximal inhibitory concentration: 1800 nM
Compound 3: middle estimate off by 6.7-fold (0.82 log units), on the high side; the measured number lies below the stated range.
By their numbers in this assay, from the lowest: compound 2; then compound 3; then compound 1.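

In this assay the change at this amine nitrogen, whose other neighbours are a saturated chain carbon and a saturated chain carbon, now has a measured size: hydrogen in place of methyl gives a result beyond the usual scatter (a 4.6-fold lower number from compound 1 to compound 3 (0.66 log units; beyond the scatter)). Within the data shown here, this is the first single-change reading, and it shows that removing this one methyl moves the compound towards stronger inhibition rather than leaving it unchanged. The pair of compound 1 and compound 2 differs in more than one place and could not show this, and nothing measured here explains the shift.

The compounds shown leave open whether a larger group on this nitrogen, such as ethyl or a longer chain, would push the number higher still; only methyl and hydrogen appear at this position, so one step gives a direction for this pair and no trend. From the compounds shown here alone, whether the same change gives a step of similar size on a core that also carries a fluorine substituent stays open too.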